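Phenyl analogue of compound 1: expected antiproliferative potency

The compounds below may be only part of what the source reports. "The series", "measured", "known", "first", "only" and "open" are said of these compounds alone.

Going by the values given here, compound 1 `Cc1ccc(N2CCN(Cn3nc(-c4ccc5c(c4)OCCO5)oc3=S)CC2)c(C)c1` gives 28400 nM in a functional assay on HepG2 cells (Homo sapiens) for antiproliferative activity, read by MTT assay, with a stated time of 48 h (on this read-out lower numbers stand for stronger inhibition and higher numbers for weaker inhibition), the highest of the two numbers measured so far; its nearest neighbour is compound 2 `S=c1oc(-c2ccc3c(c2)OCCO3)nn1CN1CCN(c2ccccc2Cl)CC1`, which gives 11400 nM in this assay. Among the compounds with values here, the one step measured, a 2.5-fold lower number from compound 1 to compound 2 (0.40 log units; beyond the scatter), follows the change 2-chlorophenyl in place of 2,4-dimethylphenyl on an amine nitrogen in a ring.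

Compound 3 `S=c1oc(-c2ccc3c(c2)OCCO3)nn1CN1CCN(c2ccccc2)CC1` differs from compound 1 by phenyl in place of 2,4-dimethylphenyl on an amine nitrogen in a ring. It has not been measured in this assay. The step from compound 1 to compound 2 bears on it only loosely: it shows that exchanging the aryl group on the amine nitrogen in the ring moved the number by a modest amount, beyond the scatter, towards a lower number, but the group entering there was 2-chlorophenyl, not phenyl, so its direction cannot simply be carried over. Phenyl carries neither the two methyl groups of compound 1 nor the chlorine of compound 2. A step of at most modest size is therefore expected, more likely towards a lower number than a higher one, and possibly none beyond the scatter. The expected step is a 1.6-fold lower number from compound 1 to compound 3 (0.20 log units; within the scatter). For compound 3 the estimate in this assay is 18000 nM, with a range from 7000 nM to 45000 nM.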

Compound 3, half-maximal inhibitory concentration: > 50000 nM
Compound 3: only a limit was reported; the forecaster's own chance of this, stated with the estimate: 10%; middle value at least 2.7-fold (0.44 log units) away from the limit.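

For compound 3 the reading in this assay is a limit and not a number: the limit of > 50000 nM in this assay, at which 1 of the 3 values shown sits.

Hydrogen in place of chloro on an aromatic carbon gives an at least 4.3-fold higher number from compound 2 to compound 3 (0.64 log units; beyond the scatter), a step beyond the scatter, so a single substituent on the aryl group on the amine nitrogen in a ring is enough to move the number in this series, which the earlier step could not show, as it exchanged one substituted aryl group for another. Phenyl in place of 2,4-dimethylphenyl gives an at least 1.7-fold higher number from compound 1 to compound 3 (0.24 log units; that floor lies within the scatter), whose floor lies within the scatter, so compound 1 and compound 3 are not separated beyond it, and the shift seen from compound 1 to compound 2 is not one that simple removal of the methyl groups reproduces.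

Still open, from the compounds shown here alone, is whether the lower number of compound 2 belongs to chloro in particular or would also come with another group on the phenyl ring, such as fluoro, methoxy or nitrile. Also open, going by these compounds, is how a non-aromatic group on the same amine nitrogen, such as cyclohexyl, or a longer link to the aryl ring, as in benzyl, would read in this assay.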